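This account rests on a few compounds, and the source may have more. Where it says the series, first, only, none or still open, it means among the compounds named here.

Compound 1 `COC1CN(C(=O)/C=C/c2ccncc2-c2ccc3ccccc3c2)C1` — > 10000 nM
Compound 2 `CNC(=O)/C=C/c1ccncc1-c1ccc2[nH]ccc2c1` — > 10000 nM

Both measured compounds were tested in a functional assay on A549 cells (Homo sapiens) for inhibition, read by sulforhodamine B assay, with a stated time of 72 h; on this read-out lower numbers stand for stronger inhibition of growth and higher numbers for weaker inhibition of growth. Compound 1 gives > 10000 nM in this assay, which is a limit of the measurement and not a number. Compound 2 gives > 10000 nM in this assay, again a limit rather than a number. Among the measured compounds shown here, the two results both sit at the limit of > 10000 nM in this assay, at which 2 of the 2 values shown sit, so no step between them can be read, and compound 1 stands only at a limit, with nothing in the numbers to place it higher or lower.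

Compound 3 `CNC(=O)/C=C/c1ccncc1-c1ccc2ccccc2c1` has not yet been measured in this assay. It differs from compound 1 in one place: methylamino in place of 3-methoxyazetidin-1-yl on a carbonyl carbon. Compound 2 already carries a methylamino group on its carbonyl carbon and was still reported only as a limit.

In this assay the step that the limit leaves unreadable from compound 1 to compound 3 is expected to be none beyond the scatter. Compound 3 is estimated at 15000 nM, with a range from 4000 nM to 50000 nM, and the result may well be reported as a limit once more.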

Compound 3, concentration for 50% growth inhibition: 6620 nM
The estimate for compound 3 lay 2.3-fold (0.36 log units) above the measured number; low and high end bracket the measured number.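

Among the compounds shown here, compound 3 is the first compound here to give a number rather than a limit in this assay, so the group on the carbonyl carbon now has one firm reading to compare against. From the compounds shown here alone, putting methylamino in place of 3-methoxyazetidin-1-yl gives an at least 1.5-fold lower number from compound 1 to compound 3 (0.17 log units; that floor lies within the scatter) and that figure is only a floor, so the true size of the step remains unknown and could be small or considerably larger. Methylamino alone does not ensure a number in this set, since compound 2 carries the same group on its carbonyl carbon and is still reported only as a limit.

Going by these compounds, it remains open how the number would respond to other groups on the same carbonyl carbon, such as a plain amino group, ethylamino, or an azetidin-1-yl ring without its methoxy group. Beyond the floor given for the change from compound 1, no step among these compounds can be read, and the values at the limit give no order among themselves: the limit of > 10000 nM in this assay, at which 2 of the 3 values shown sit.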